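A few compounds are considered here, and "the series" means these few. Any claim that something is new, unique, unknown or untested is made for them only; others in the source may bear on it.

In a functional assay on HeLa cells (Homo sapiens) for inhibition, read by CCK-8 assay, with a stated time of 72 h (on this read-out higher numbers stand for weaker inhibition and lower numbers for stronger inhibition), compound 1 `Nc1ccccc1NC(=O)c1ccc(CNC(=O)c2n[nH]cc2NC(=O)c2c(F)cccc2Cl)cc1` gives 3270 nM and compound 2 `Nc1ccccc1NC(=O)c1ccc(CNC(=O)c2n[nH]cc2NC(=O)c2ccccc2Cl)cc1` gives 10500 nM as the higher of the two numbers. Compound 3 `Nc1ccccc1NC(=O)c1ccc(CNC(=O)c2n[nH]cc2NC(=O)c2ccccc2)cc1` differs from compound 2 by hydrogen in place of chloro on an aromatic carbon with hydrogen in place of chloro on an aromatic carbon, ortho to a large group, so 2-chlorophenyl becomes phenyl. Going by the values given here, the one measured step that bears on this is a 3.2-fold higher number from compound 1 to compound 2 (0.51 log units; beyond the scatter) and it removed fluoro rather than chloro, so it guides the expectation only loosely. A small further rise in this assay is expected, possibly no larger than the scatter. The estimate means an expected 1.5-fold higher number from compound 2 to compound 3 (0.18 log units; within the scatter) as the step. For compound 3 the expected value is 16000 nM with 6000 nM to 40000 nM as the estimated range.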

Compound 3, half-maximal inhibitory concentration: 4060 nM
Compound 3: the middle estimate sits 3.9-fold (0.60 log units) above what was measured; measured number below the stated range.
By their numbers in this assay, from the lowest: compounds 1 and 3 (each within the scatter of the next); then compound 2.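

In this assay taking the chloro off the 2-chlorophenyl gives a 2.6-fold lower number from compound 2 to compound 3 (0.41 log units; beyond the scatter) and so runs opposite to the earlier loss of fluoro from the same ring, which gave a 3.2-fold higher number from compound 1 to compound 2 (0.51 log units; beyond the scatter) as its step. Losing both halogens together amounts to a 1.2-fold higher number from compound 1 to compound 3 (0.09 log units; within the scatter) and so the two changes do not add up across these three compounds. Only compound 2, with the lone chloro, stands apart from the other two, and the plain benzoyl of compound 3 costs nothing measurable against the doubly halogenated ring of compound 1.

Open, as far as these compounds go, is whether a lone fluoro or a methoxy group in place of the chloro would track compound 2 or compound 3. No measured property of these compounds accounts for this reversal.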